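Aryl amino group replacing the alkynyl ester of compound 3

The source may report more compounds than this note shows. Statements on the series, on what has been measured and on what is new or still open speak of the compounds shown alone.

For the measured compounds named here, in a functional assay on MCF7 cells (Homo sapiens) for antiproliferative activity, read by MTT assay, with a stated time of 48 h (a lower number here means a stronger inhibitor, a higher number a weaker inhibitor), compound 1 `CCn1c(C(=O)NCCN(C)C)ccc1C(CC)(CC)c1ccc(OCCC(O)(CC)CC)c(C)c1` gives 430 nM and is the only compound so far with a number. Compound 2 `CCn1c(C(=O)N(CCC#N)CCC#N)ccc1C(CC)(CC)c1ccc(OCCC(O)(CC)CC)c(C)c1` reads > 50000 nM which is a limit of the assay. Compound 3 `C#CCCOC(=O)c1ccc(C(CC)(CC)c2ccc(OCCC(O)(CC)CC)c(C)c2)n1CC` reads > 50000 nM which is also a limit. Compound 3 therefore has no number of its own (the limit of > 50000 nM in this assay, at which 2 of the 3 values shown sit).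

Compound 4 `CCn1c(C(=O)Nc2cccc(C(F)(F)F)c2)ccc1C(CC)(CC)c1ccc(OCCC(O)(CC)CC)c(C)c1` differs from it as follows: (3-(trifluoromethyl)phenyl)amino in place of (but-3-yn-1-yl)oxy on a carbonyl carbon with (3-(trifluoromethyl)phenyl)amino in place of (but-3-yn-1-yl)oxy on the carbonyl carbon. Two large steps at this carbonyl carbon bear on the change: an at least 110-fold higher number from compound 1 to compound 3 (2.06 log units; beyond the scatter) and an at least 110-fold higher number from compound 1 to compound 2 (2.06 log units; beyond the scatter) both lie beyond the scatter and both lead to a limit. Compound 4 regains an amino link like that of compound 1 430 nM but not its (2-(dimethylamino)ethyl)amino group, so only a partial return is expected. The expected change is an at least 3.3-fold lower number from compound 3 to compound 4 (0.52 log units; beyond the scatter) toward a lower number in this assay and a reading at the limit remains quite possible. The estimate for compound 4 is 15000 nM (expected range 2500 nM to 50000 nM).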

Compound 4, half-maximal inhibitory concentration: > 50000 nM
Compound 4: only a limit was reported; the forecaster's own chance of this, stated with the estimate: 45%; middle value at least 3.3-fold (0.52 log units) away from the limit.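

In this assay compound 4 keeps the amide hydrogen, yet its reading of > 50000 nM is a limit of the assay and not a number. For the compounds shown here, an amino link on the carbonyl carbon is therefore not enough on its own: with 3-(trifluoromethyl)phenyl in place of 2-(dimethylamino)ethyl on the amide-type nitrogen, the series shows an at least 110-fold higher number from compound 1 to compound 4 (2.06 log units; beyond the scatter) and compound 1 remains the only compound with a number. The steps from compound 2 and compound 3 to compound 4 cannot be read: the limit of > 50000 nM in this assay, at which 3 of the 4 values shown sit.

Still open, going by these compounds, is whether the number of compound 1 depends on the dimethylamino nitrogen itself or on the two-carbon chain that carries it. A 2-methoxyethyl amide, a 2-(pyrrolidin-1-yl)ethyl amide or a free carboxylic acid on the carbonyl carbon would separate these readings.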